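A few compounds are considered here, and "the series" means these few. Any claim that something is new, unique, unknown or untested is made for them only; others in the source may bear on it.

Measured compounds in an assay on cells for displacement of a labelled ligand from adenosine receptor A1 (Homo sapiens), read by scintillation counting and radioligand binding, with a stated time of 60 min, tested at 10 uM; a higher number here means more inhibition at the concentration tested (going by the name of the read-out), a lower number less inhibition:
Compound 1 `CN1CCN(c2nc(-c3ccc(Cl)c(Cl)c3)nc3[nH]cnc23)CC1` gives > 80%.
Compound 2 `CN1CCN(c2nc(-c3ccc(Cl)c(C(F)(F)F)c3)nc3[nH]cnc23)CC1` gives 52.4%.
Compound 3 `CN1CCN(c2nc(-c3ccc(Cl)c(Cl)c3)nc3c2ncn3C)CC1` gives 65.2%.

Compound 1 is known only as a limit, (the limit of > 80% in this assay, at which 1 of the 3 values shown sits), so its true value is open. Both measured steps lead away from it: a number at least 27.6 percentage points lower from compound 1 to compound 2 (beyond the scatter) and a number at least 14.8 percentage points lower from compound 1 to compound 3 (beyond the scatter).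

Compound 4 `CN1CCN(c2nc(-c3ccc(O)cc3)nc3[nH]cnc23)CC1` is not yet measured. It differs from compound 1 by 4-hydroxyphenyl in place of 3,4-dichlorophenyl on an aromatic carbon. For the measured compounds named here, no measured step replaces this aryl group as a whole; the nearest is the step on the same aryl group, a number at least 27.6 percentage points lower from compound 1 to compound 2 (beyond the scatter), which lowered the read-out beyond the scatter with a smaller alteration than the one to compound 4. The other step, a number at least 14.8 percentage points lower from compound 1 to compound 3 (beyond the scatter), touches a different part of the shared core. Going by the values given here, since both changes from compound 1 lowered the read-out, the larger change to compound 4 is expected to lower it as well; the expected step is a number at least 40 percentage points lower from compound 1 to compound 4 (beyond the scatter), its size uncertain because only two steps are known and compound 1 itself sits at a limit. For compound 4 the estimate in this assay is 40%, with a range from 10% to 75%.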

Compound 4, a percentage reported as inhibition, at one concentration (the size of the read-out at that concentration, not a potency): > 80%
Compound 4: only a limit was reported; the forecaster's own chance of this, stated with the estimate: 15%; middle value at least 40 percentage points from the limit.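

Compound 1 and compound 4 both stand at a limit in this assay, so no step can be read between them: the limit of > 80% in this assay, at which 2 of the 4 values shown sit.

The compounds shown leave open how far apart the true values of compound 1 and compound 4 lie, and whether 4-hydroxyphenyl in place of 3,4-dichlorophenyl changes the read-out in this assay at all.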